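Amino for hydroxy on a shared quinazoline-free core: inactive neighbours

A few compounds are considered here, and "the series" means these few. Any claim that something is new, unique, unknown or untested is made for them only; others in the source may bear on it.

Compound 2 `Oc1ccccc1Nc1nc(-c2cccc(F)c2)nc2ccc(F)cc12` was tested in a functional assay on MDA-MB-231 cells (Homo sapiens) for cytotoxicity, read by MTT assay, with a stated time of 48 h; on this read-out lower numbers stand for stronger inhibition and higher numbers for weaker inhibition. Compound 2 gives > 50000 nM in this assay, and this is a limit of the measurement rather than a number. Its neighbour compound 1 `Fc1cccc(-c2nc(Nc3ccc(Cl)cc3)c3cc(F)ccc3n2)c1` was measured in the same way. Compound 1 gives > 50000 nM in this assay, again a limit. The step that the two limits leave unreadable from compound 1 to compound 2 therefore cannot be read, as the limit of > 50000 nM in this assay, at which 2 of the 2 values shown sit, shows.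

Compound 3 `Nc1ccccc1Nc1nc(-c2cccc(F)c2)nc2ccc(F)cc12` is not yet measured. It differs from compound 2 by amino in place of hydroxy on an aromatic carbon. Among the measured compounds shown here, no measured step bears directly on this change, since the only step on hand, a step that the two limits leave unreadable from compound 1 to compound 2, is itself unreadable, and both values known so far sit at the same limit described by the limit of > 50000 nM in this assay, at which 2 of the 2 values shown sit.

Compound 3 is expected to remain near that limit in this assay, with an estimate of 50000 nM, between 15000 nM and 150000 nM. The expected step of a number no higher from compound 2 to compound 3 (the limit leaves the size open) is therefore set at nothing beyond the scatter, and the most likely outcome for compound 3 is again a reported limit rather than a number.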

Compound 3, half-maximal inhibitory concentration: > 50000 nM
Compound 3 was reported as a limit; the forecaster's own chance of this, stated with the estimate: 80%; the middle value sits exactly at the limit.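

No step can be read among compound 1, compound 2 and compound 3, so the change to amino shows no measurable effect either way, as all three results are limits: the limit of > 50000 nM in this assay, at which 3 of the 3 values shown sit.

The compounds shown leave open whether amino in place of hydroxy on an aromatic carbon alters cytotoxicity at all, for none of them yields a number.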